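Series notes: from compound 3 to compound 4

The compounds below may be only part of what the source reports. "The series", "measured", "known", "first", "only" and "open" are said of these compounds alone.

Compound 3 `Cc1ccc(-c2nnc(-c3ccc(CN4CCN(C)CC4)c(C(F)(F)F)c3)o2)cc1Nc1nccc(-c2cccnc2)n1` gives 510 nM in a functional assay on K562 cells (Homo sapiens) for inhibition, read by MTT assay, with a stated time of 72 h (a lower number here means a stronger inhibitor, a higher number a weaker inhibitor), the lowest of the three numbers recorded so far. Compound 1 `Cc1ccc(-c2cn(-c3ccc(CN4CCN(C)CC4)cc3)nn2)cc1Nc1nccc(-c2cccnc2)n1` gives 4700 nM and compound 2 `Cc1ccc(-c2nnc(-c3ccc(CN4CCN(C)CC4)cc3)o2)cc1Nc1nccc(-c2cccnc2)n1` gives 4900 nM, each standing higher than compound 3 by a margin beyond the scatter. Going by the values given here, the only single-point step measured is a 9.6-fold lower number from compound 2 to compound 3 (0.98 log units; beyond the scatter). Compound 4 `Cc1ccc(-c2nnc(-c3ccc(C)c(C(F)(F)F)c3)o2)cc1Nc1nccc(-c2cccnc2)n1` differs from compound 3 by hydrogen in place of 4-methylpiperazin-1-yl on a saturated chain carbon bound to an aromatic carbon. Among the compounds with values here, no measured step touches this change: compounds 1, 2 and 3 all carry the (4-methylpiperazin-1-yl)methyl group, so the recorded numbers give no guide to its removal; the trifluoromethyl of compound 3 is retained. The step expected is a 2.9-fold higher number from compound 3 to compound 4 (0.47 log units; beyond the scatter), a rise with wide uncertainty. Compound 4 is estimated at 1500 nM, range 400 nM to 6000 nM.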

Compound 4, half-maximal inhibitory concentration: > 30000 nM
Compound 4: a limit, no number (the forecaster's own chance of this, stated with the estimate: 5%); middle value at least 20-fold (1.30 log units) away from the limit.
By their numbers in this assay, from the lowest: compound 3; then compounds 1 and 2 (each within the scatter of the next). At a limit, above all of these: compound 4.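

In this assay compound 4 reads > 30000 nM, a limit of the assay and not a number: the limit of > 30000 nM in this assay, at which 1 of the 4 values shown sits. Cutting (4-methylpiperazin-1-yl)methyl to methyl, with the trifluoromethyl kept, gives an at least 58-fold higher number from compound 3 to compound 4 (1.76 log units; beyond the scatter). Going by these compounds alone, this is the first reading of that group's removal, and it shows that inhibition depends heavily on what sits on this saturated chain carbon bound to an aromatic carbon.

From the compounds shown here alone, whether the whole 4-methylpiperazin-1-yl group is needed stays open. So does how a dimethylamino group, a morpholine or a carboxylic acid would read at this place.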